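This account rests on a few compounds, and the source may have more. Where it says the series, first, only, none or still open, it means among the compounds named here.

Measured so far:
- compound 1 `COc1cccc(/C=C/C(=O)C(=Cc2ccc(F)cc2)C(=O)/C=C/c2cccc(OC)c2OC)c1OC`: 1040 nM
- compound 2 `COc1cc(OC)c(C=C(C(=O)/C=C/c2cccc(OC)c2OC)C(=O)/C=C/c2cccc(OC)c2OC)c(OC)c1`: 840 nM
- compound 3 `COc1cccc(/C=C/C(=O)C(=Cc2ccc(O)c(F)c2)C(=O)/C=C/c2cccc(OC)c2OC)c1OC`: 330 nM

These three compounds were tested in a functional assay on SW480 cells (Homo sapiens) for antiproliferative activity, read by sulforhodamine B assay, with a stated time of 48 h; a lower number here means a stronger inhibitor, a higher number a weaker inhibitor. Compound 3 has the lowest number of the three: compared with compound 2 the step is a 2.5-fold lower number from compound 2 to compound 3 (0.41 log units; beyond the scatter), and compared with compound 1 it is a 3.2-fold lower number from compound 1 to compound 3 (0.50 log units; beyond the scatter), both beyond the scatter, so compound 3 is the strongest inhibitor among them. Compound 2 and compound 1 differ only by a 1.2-fold lower number from compound 1 to compound 2 (0.09 log units; within the scatter), which is within the scatter.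

Compound 4 `COc1cccc(/C=C/C(=O)C(=Cc2ccc(OC)c(OC)c2OC)C(=O)/C=C/c2cccc(OC)c2OC)c1OC` has not yet been measured. It differs from compound 3 in one place: 2,3,4-trimethoxyphenyl in place of 3-fluoro-4-hydroxyphenyl on a double-bonded chain carbon bound to a double-bonded chain carbon. The closest guide is the step between compound 2 and compound 3, where a 2,4,6-trimethoxyphenyl gave way to the 3-fluoro-4-hydroxyphenyl and the number fell by a 2.5-fold lower number from compound 2 to compound 3 (0.41 log units; beyond the scatter). Walking back to a trimethoxyphenyl, now the 2,3,4-trimethoxyphenyl, is expected to undo much of that gain, giving a modest step upward of about a 2.4-fold higher number from compound 3 to compound 4 (0.38 log units; beyond the scatter) in this assay. Compound 4 is therefore estimated at 800 nM, with a range from 350 nM to 1800 nM.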

Compound 4, half-maximal inhibitory concentration: 560 nM
Estimate against measurement, compound 4: 1.4-fold (0.15 log units) above; measured number inside the range.
By their numbers in this assay, from the lowest: compounds 3, 4, 2 and 1 (each within the scatter of the next, the first and the last beyond it).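

In this assay the 3-fluoro-4-hydroxyphenyl no longer stands clearly apart at this place: a 1.7-fold higher number from compound 3 to compound 4 (0.23 log units; within the scatter) is the step to a group with no hydrogen-bond donors. Changing the methoxy pattern from 2,4,6-trimethoxyphenyl to 2,3,4-trimethoxyphenyl gives only a 1.5-fold lower number from compound 2 to compound 4 (0.18 log units; within the scatter) and so shows no clear effect of that arrangement here. Among the compounds shown here, replacing 4-fluorophenyl with the new group gives a 1.9-fold lower number from compound 1 to compound 4 (0.27 log units; within the scatter) as well, so this one group lies within the scatter of two others that the earlier compounds held apart.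

Only substituted phenyl rings appear at this place, so a ring carrying an amine or a carboxylic acid, or a longer chain in place of the ring, remains an open question. No accompanying measurement explains why these groups give such similar numbers.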